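A few compounds are considered here, and "the series" means these few. Any claim that something is new, unique, unknown or untested is made for them only; others in the source may bear on it.

Measured compounds in the series:
- compound 1, `O=c1[nH]cc(S(=O)(=O)Nc2ccccc2-c2cn(-c3cccc(Cl)c3)nn2)c(=O)[nH]1` — 2460 nM
- compound 2, `Cc1ccccc1-n1cc(-c2cccc(NS(=O)(=O)c3c[nH]c(=O)[nH]c3=O)c2)nn1` — 9570 nM
- compound 3, `Cc1ccc(-n2cc(-c3ccc(NS(=O)(=O)c4c[nH]c(=O)[nH]c4=O)cc3)nn2)cc1` — 11600 nM

All three values come from a functional assay on HepG2 cells (Homo sapiens) for antiproliferative activity, read by MTT assay, with a stated time of 24 h; on this read-out higher numbers stand for weaker inhibition and lower numbers for stronger inhibition. Compound 3 gives the highest number of the three. Against compound 2 the gap is within the scatter, so no order between compound 2 and compound 3 can be read from these numbers. Against compound 1 the gap lies beyond the scatter; compound 1 gives the lowest number of the set.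

Compound 4, `O=c1[nH]cc(S(=O)(=O)Nc2ccc(-c3cn(-c4ccccc4Cl)nn3)cc2)c(=O)[nH]1`, has not yet been measured in this assay. It differs from compound 3 in one place: 2-chlorophenyl in place of 4-methylphenyl on an aromatic nitrogen. Within the data shown here, no pair that differs in exactly this way has been measured, so no step of this kind is known. Compound 1 carries a chlorophenyl on the same ring nitrogen and gives the lowest number, but it also differs from compound 4 elsewhere, so it cannot serve as a direct guide. A small step from compound 3 to compound 4, towards a lower number, is expected, though one within the scatter cannot be excluded. The expected step is a 1.8-fold lower number from compound 3 to compound 4 (0.25 log units; within the scatter). For compound 4 the estimate in this assay is 6500 nM, with a range from 2500 nM to 15000 nM.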

Compound 4, half-maximal inhibitory concentration: 2230 nM
Estimate against measurement, compound 4: 2.9-fold (0.46 log units) above; the whole stated range lies above it.
By their numbers in this assay, from the lowest: compounds 4 and 1 (each within the scatter of the next); then compounds 2 and 3 (each within the scatter of the next).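

Among these compounds, replacing 4-methylphenyl with 2-chlorophenyl on the aromatic nitrogen gives a 5.2-fold lower number from compound 3 to compound 4 (0.72 log units; beyond the scatter) in this assay and is the first change at a single place to read beyond the scatter. The earlier compounds shown here all differed in more than one place, so none could isolate this position; this step shows that the group on this nitrogen can alone shift the number on the shared core. Nothing at hand accounts for the size of the step.

The step swaps the substituent and its place on the phenyl ring together, so it cannot say which of the two carries the change. As far as these compounds go, how a plain phenyl, a benzyl or a cyclohexyl group on the same nitrogen would read remains open.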